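The source may report more compounds than this note shows. Statements on the series, on what has been measured and on what is new or still open speak of the compounds shown alone.

Among the compounds with values here, compound 1, `COc1ccc(-c2cc(-c3ccccc3)n[nH]2)cc1`, is one of two compounds measured so far in a functional assay on SW-620 cells (Homo sapiens) for inhibition, read by MTT assay, with a stated time of 48 h (a higher number here means a weaker inhibitor of growth, a lower number a stronger inhibitor of growth), and in this assay compound 1 gives 27200 nM, the highest of the two numbers. Compound 2, `COc1ccc(-c2cc(-c3ccc(C(F)(F)F)cc3)n[nH]2)cc1`, carries a trifluoromethyl group on an aromatic carbon in place of a hydrogen; in this assay compound 2 gives 11200 nM. Within the data shown here, the step of a 2.4-fold lower number from compound 1 to compound 2 (0.39 log units; beyond the scatter) is the only measured step, and it shows that adding a group to an aromatic carbon can lower the number modestly. Compound 3, `COc1ccc(-c2cc(-c3ccccc3-c3ccccc3)n[nH]2)cc1`, is not yet measured. It differs from compound 1 by phenyl in place of hydrogen on an aromatic carbon. The measured step bears on this only loosely, since the entering group and its place differ, so a modest lowering is expected with wide uncertainty, and the expected step is a 1.8-fold lower number from compound 1 to compound 3 (0.26 log units; within the scatter). Compound 3 is therefore expected to give about 15000 nM, within a range from 5000 nM to 45000 nM.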

Compound 3, concentration for 50% growth inhibition: 890 nM
The estimate for compound 3 lay 17-fold (1.23 log units) above the measured number; the whole stated range lies above it.
By their numbers in this assay, from the lowest: compound 3; then compound 2; then compound 1.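

Placed on an aromatic carbon ortho to a large group, phenyl gives a 31-fold lower number from compound 1 to compound 3 (1.49 log units; beyond the scatter) in this assay, a far larger change than the modest 2.4-fold lower number from compound 1 to compound 2 (0.39 log units; beyond the scatter). So a single group added to the core of compound 1 can shift the number by much more than the first step suggested, and this place on the core can carry a whole six-membered aromatic ring with a large lowering of the number. Within the data shown here, nothing available here explains why this change lowers the number so far.

On these data alone, it remains open whether the lowering needs a ring at all, or whether a smaller group such as methyl or chlorine at the same place would also lower the number. As far as these compounds go, it is equally open how an amine or a carboxylic acid on the entering phenyl would alter the result.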